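The source may report more compounds than this note shows. Statements on the series, on what has been measured and on what is new or still open speak of the compounds shown alone.

Of the compounds shown here, three that share a core have been measured in a physicochemical assay for lipophilicity, read by HPLC, at pH 7.5; a lower number here means a more polar compound, a higher number a more lipophilic compound. Compound 1 `CCOc1ccccc1-c1ccc(-c2nc3cnccc3c(NC(C)C(=O)O)c2C#N)cc1` gives 2.1, compound 2 `CC[C@@H](Nc1c(C#N)c(-c2ccc(-c3ncccc3C)cc2)nc2cnccc12)C(N)=O` gives 2 and compound 3 `CC[C@H](Nc1c(C#N)c(-c2ccc(Br)cc2)nc2cnccc12)C(N)=O` gives 2.3. All three numbers lie within the usual scatter of one another, so compound 2 cannot be told apart from either neighbour.

Compound 4 `CC[C@@H](Nc1c(C#N)c(-c2ccc(-c3cccc(Cl)c3OC)cc2)nc2cnccc12)C(N)=O` has not been measured yet. It differs from compound 2 in one place, on an aromatic carbon of a six-membered aromatic ring of carbon only, para to a large group: 3-chloro-2-methoxyphenyl in place of 3-methylpyridin-2-yl on an aromatic carbon. The group that leaves has a ring with a hetero atom, while the group that enters has a ring of carbon only and carries a chlorine. Going by the values given here, no measured pair shows a change of this kind, so the expectation is a judgement from the structures alone. In this assay a move to a higher number, beyond the scatter, is expected, with an estimated a number 1.00 log units higher from compound 2 to compound 4 (beyond the scatter). For compound 4 the estimated value is 3, with an expected range from 2.5 to 3.6.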

Compound 4, distribution coefficient: 3.1
Compound 4: middle estimate off by 0.10 log units, on the low side; the measured number falls inside the stated range.
By their numbers in this assay, from the lowest: compounds 2, 1 and 3 (each within the scatter of the next); then compound 4.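

Going by these compounds alone, at this place, on an aromatic carbon of a six-membered aromatic ring of carbon only, para to a large group, 3-chloro-2-methoxyphenyl in place of 3-methylpyridin-2-yl gives the first readable one-place change in this assay: a number 1.10 log units higher from compound 2 to compound 4 (beyond the scatter). Within the data shown here, the three earlier compounds lie within the scatter of one another and include no pair differing in one place, so they could not show that a change here alone can move the number this far. Nothing available here bears on why the number moves.

On these data alone, this single step changes the ring atoms and adds a chlorine and a methoxy group together, so the share of each remains open. A plain phenyl ring, a 3-chlorophenyl group or a 2-methoxyphenyl group at this place would help to separate them.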